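Adding a Second Chloro to a Dichloropurine Core

The source may report more compounds than this note shows. Statements on the series, on what has been measured and on what is new or still open speak of the compounds shown alone.

Compound 1 `ClCc1cccc(Cn2cnc3ncnc(Cl)c32)c1`: 5240 nM
Compound 2 `ClCc1ccccc1Cn1cnc2ncnc(Cl)c21`: 4070 nM
Compound 3 `ClCc1cccc(Cn2cnc3nc(Cl)nc(Cl)c32)c1`: 1990 nM

In a functional assay on HCT-116 cells (Homo sapiens) for cytotoxicity, read by sulforhodamine B assay, with a stated time of 48 h (a lower number here means a stronger inhibitor of growth, a higher number a weaker inhibitor of growth), compound 1 gives 5240 nM and compound 3 gives 1990 nM. Compound 3 differs from compound 1 by one change, (chloro in place of hydrogen on an aromatic carbon), and this change made a 2.6-fold lower number from compound 1 to compound 3 (0.42 log units; beyond the scatter). Compound 2 `ClCc1ccccc1Cn1cnc2ncnc(Cl)c21` has the same atoms as compound 1 but joined differently; the difference between the two cores is not broken down here. In this assay compound 2 gives 4070 nM, which sits within the scatter of compound 1 and stands higher than compound 3, beyond the scatter.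

Compound 4 `ClCc1ccccc1Cn1cnc2nc(Cl)nc(Cl)c21` has not been measured. It differs from compound 2 by chloro in place of hydrogen on an aromatic carbon, the same change that turned compound 1 into compound 3, at the same place. Because that earlier change gave a 2.6-fold lower number from compound 1 to compound 3 (0.42 log units; beyond the scatter), a step of about the same size is expected here, and the step from compound 2 to compound 4 is estimated at a 2.5-fold lower number from compound 2 to compound 4 (0.41 log units; beyond the scatter). Among the measured compounds shown here, with only one prior example, this expectation is tentative. For compound 4 the expected value in this assay is 1600 nM, with a plausible range from 800 nM to 3300 nM.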

Compound 4, concentration for total growth inhibition: 4070 nM
For compound 4 the middle estimate is 2.5-fold (0.41 log units) below the measured one, and the stated range ends below it.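

In this assay, chloro in place of hydrogen on the aromatic carbon between two ring nitrogen atoms gives no change at the digits printed from compound 2 to compound 4 (within the scatter). At first sight this looks unlike the earlier result, yet the gap between the two steps is no larger than repeated measurements could produce on their own: the same change on two cores in this assay, a 2.6-fold lower number (0.42 log units; beyond the scatter) from compound 1 to compound 3 and no change at the digits printed (within the scatter) from compound 2 to compound 4, 2.6-fold (0.42 log units) apart, within the scatter of two such steps. The data therefore do not show that the change carries over from the core of compound 1 to the core of compound 2, and they do not show that it fails to carry over, as a single step on each core cannot settle the question.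

Going by these compounds, what remains open is whether a repeat of these steps would bring them closer together or pull them further apart, and how the change behaves on any other core. Also open, on these data alone, is whether another group on that same carbon, such as an amine or a methoxy group, would move the number in either direction.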